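A few compounds are considered here, and "the series" means these few. Any claim that something is new, unique, unknown or untested is made for them only; others in the source may bear on it.

Measured so far:
Compound 1, `CCC(=O)NCCC1CCc2ccccc2N1Cc1ccccc1`: 326 nM
Compound 2, `CCNC(=O)NCC1CCc2c(cccc2OC)N1`: 480 nM

Two compounds carry the shared core of compound 1 and have been tested in an assay on CHO cells for displacement of a labelled ligand from melatonin receptor type 1A (Homo sapiens), with a stated time of 120 min; on this read-out lower numbers stand for stronger inhibition and higher numbers for weaker inhibition. Compound 1 gives 326 nM there, the lowest of the two numbers, while compound 2 gives 480 nM; the gap between them lies within the scatter, so neither can be called the stronger binder. No pair of these compounds differs in a single place, so no measured step is available to calibrate the change that is now considered.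

The unmeasured compound 3, `CCC(=O)NCC1CCc2ccccc2N1Cc1ccccc1`, arises from compound 1 by the change (propanoylamino in place of (propanoylamino)methyl on a saturated chain carbon bound to a saturated ring carbon). The side chain is thus shortened, and nothing else moves. Going by the values given here, with no comparable step on record, the size and direction of this change can only be guessed; he expects a step from compound 1 to compound 3 of a 1.5-fold higher number from compound 1 to compound 3 (0.19 log units; within the scatter) in this assay, a modest weakening that may not exceed the scatter. His estimate for compound 3 in this assay is 500 nM, with a range from 150 nM to 1800 nM.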

Compound 3, inhibition constant: 37 nM
Estimate against measurement, compound 3: 14-fold (1.13 log units) above; measured number outside the range, below it.
By their numbers in this assay, from the lowest: compound 3; then compounds 1 and 2 (each within the scatter of the next).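

In this assay, the change from 2-(propanoylamino)ethyl to (propanoylamino)methyl gives an 8.8-fold lower number from compound 1 to compound 3 (0.95 log units; beyond the scatter), the first measured step among these compounds, and it shows that the length of this side chain matters for the read-out. The two groups have the same counts of hydrogen-bond donors, hydrogen-bond acceptors and double bonds, and neither carries a net charge, so the step is not accompanied by a difference in any of these counts. Nothing available here accounts for the lower number of the shorter chain.

This single step covers only two chain lengths, so the compounds shown do not tell whether the number would fall further with an amide attached directly to the saturated ring carbon, or how a 3-(propanoylamino)propyl chain would compare. They also leave open how much depends on the propanoyl part itself, as against an acetyl or butanoyl group or a free amine in its place, and compound 2 differs from compound 1 and compound 3 in more than one place, so it cannot answer this.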